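Sulfur position in the lower chain of prostanoid analogues

The compounds below may be only part of what the source reports. "The series", "measured", "known", "first", "only" and "open" are said of these compounds alone.

Within the data shown here, compound 2, `CCCCC[C@H](O)/C=C/[C@H]1[C@H](O)CC(=O)[C@@H]1CSCCCCC(=O)O`, is the only one of the pair with a numerical result: in an assay on CHO cells for binding affinity to prostaglandin E2 receptor EP1 subtype (Mus musculus) (on this read-out lower numbers stand for stronger inhibition and higher numbers for weaker inhibition), compound 2 gives 95 nM. Compound 1, `COCc1cccc(C[C@H](O)/C=C/[C@H]2[C@H](O)CC(=O)[C@@H]2CCSCCCC(=O)O)c1`, reaches only a limit, and in this assay compound 1 gives > 10000 nM. The limit of > 10000 nM in this assay, at which 1 of the 2 values shown sits, is the only other entry in this assay and belongs to a compound that differs from compound 2 in more than one place, so it cannot be read as a step. Compound 3, `CCCCC[C@H](O)/C=C/[C@H]1[C@H](O)CC(=O)[C@@H]1CCSCCCC(=O)O`, is not yet measured in this assay. Its difference from compound 2 is ((3-carboxypropyl)sulfanyl)methyl in place of (4-carboxybutyl)sulfanyl on a saturated chain carbon bound to a saturated ring carbon; the same atoms are joined differently, with the sulfur one position farther out. Among the measured compounds shown here, no measured step isolates this change. A modest loss is expected, so that from compound 2 to compound 3 the step is estimated at a 3.7-fold higher number from compound 2 to compound 3 (0.57 log units; beyond the scatter). Compound 3 is expected at 350 nM, within 70 nM to 3000 nM.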

Compound 3, inhibition constant: 52 nM
Estimate against measurement, compound 3: 6.7-fold (0.83 log units) above, outside the stated range (below it).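

In this assay, the sulfur can sit one position farther out without a change beyond the usual scatter: the step is a 1.8-fold lower number from compound 2 to compound 3 (0.26 log units; within the scatter), so the two placements cannot be told apart on this read-out. With the ((3-carboxypropyl)sulfanyl)methyl chain held constant, butyl in place of 3-(methoxymethyl)phenyl gives an at least 190-fold lower number from compound 1 to compound 3 (2.28 log units; beyond the scatter), which places the large difference at this other end of the molecule rather than at the sulfur position. That step rests on a limit and not on a number, so its true size stays unknown, and compound 1 stands at that limit: the limit of > 10000 nM in this assay, at which 1 of the 3 values shown sits.

Open, from the compounds shown here alone, is whether an unsubstituted phenyl or a hexyl chain in place of butyl would stay close to compound 3 in this assay. Also open, going by these compounds, is whether an oxygen in place of the sulfur would leave the number within the scatter of compound 2.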